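Cytotoxicity of a piperazine series: cyclohexyl to 4-fluorophenyl

The source may hold more compounds than are shown below. What is called first, only, known or untested is meant among the compounds shown, and "the series" means these compounds.

Measured compounds:
compound 1, `COc1cc2c(cc1OC)CN(CCCCn1nc(-c3ccccc3)oc1=O)CC2`, 84%
compound 2, `Cc1ccc(CN(C)CCCCn2nc(-c3ccccc3)oc2=O)c(C)c1`, 86%
compound 3, `O=C1CCc2ccccc2N1CCCCN1CCN(C2CCCCC2)CC1`, 83%

In an ADME assay on HeLa cells (Homo sapiens) for cytotoxicity, read by MTT assay, with a stated time of 48 h, tested at 10 uM (a higher number here means a weaker effect of the compound at the concentration tested, a lower number a stronger effect), the three measured compounds sit close together. Compound 1 gives 84%, compound 2 gives 86%, and compound 3 gives 83%. For the measured compounds named here, the value of compound 3 stands within the usual scatter of both others: compound 1 is nearest to it, compound 2 furthest, yet neither gap exceeds the scatter, so no compound here can be set apart from the rest.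

Compound 4, `O=C1CCc2ccccc2N1CCCCN1CCN(c2ccc(F)cc2)CC1`, is the unmeasured partner of compound 3. It differs in one place: 4-fluorophenyl in place of cyclohexyl on an amine nitrogen in a ring. No step between measured compounds is available, so the change has no precedent among these numbers. Given that compound 3 gives 83% and that all three measured compounds cluster in this assay, the step of a number 1 percentage points lower from compound 3 to compound 4 (within the scatter) is expected to stay within the scatter, in no definite direction. Compound 4 is therefore estimated at 82%, within 70% to 94%.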

Compound 4, a percentage reported as activity, at one concentration (the size of the read-out at that concentration, not a potency): 88%
Estimate against measurement, compound 4: 6 percentage points below; measured number inside the range.
By their numbers in this assay, from the lowest: compounds 3, 1, 2 and 4 (each within the scatter of the next).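

For the compounds shown here, the swap of cyclohexyl for 4-fluorophenyl on an amine nitrogen in a ring gives the only step that can be read at this position, and in this assay it is a number 5 percentage points higher from compound 3 to compound 4 (within the scatter) at the one concentration tested. Going by these compounds alone, an aromatic ring of carbon bearing fluorine and a non-aromatic ring of carbon only are therefore not told apart here, and compound 4 falls into the same cluster as the earlier compounds. Nothing measured alongside these numbers bears on this result.

From the compounds shown here alone, whether a benzyl group, an acetyl group or a carboxylic acid on that piperazine nitrogen would read the same remains open. Also open, going by these compounds, is whether a longer chain on the ring nitrogen would leave this read-out within the same cluster.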